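The source may report more compounds than this note shows. Statements on the series, on what has been measured and on what is new or still open speak of the compounds shown alone.

Three compounds have been measured in a functional assay on DU-145 cells (Homo sapiens) for inhibition; on this read-out higher numbers stand for weaker inhibition and lower numbers for stronger inhibition:

Compound 1, `Oc1cccc(-c2cc(-c3ccccc3F)cc(-c3ccccc3O)n2)c1`, gives 35600 nM.
Compound 2, `Oc1cccc(-c2cc(-c3ccccc3F)cc(-c3cccc(O)c3)n2)c1`, gives 11200 nM.
Compound 3, `Oc1cccc(-c2cc(-c3cccc(C(F)(F)F)c3)cc(-c3ccccc3O)n2)c1`, gives 13000 nM.

Among these three numbers, compound 1 stands highest, which on this read-out means the weakest inhibition. Both changes made to it so far lowered the number: a 3.2-fold lower number from compound 1 to compound 2 (0.50 log units; beyond the scatter), and a 2.7-fold lower number from compound 1 to compound 3 (0.44 log units; beyond the scatter). Each is modest, and each lies beyond the scatter of repeated measurements.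

Compound 4, `Oc1cccc(-c2cc(-c3ccccc3OC(F)(F)F)cc(-c3ccccc3O)n2)c1`, differs from compound 1 in one place: trifluoromethoxy in place of fluoro on an aromatic carbon. Of the two measured steps, the one that bears on this change is a 2.7-fold lower number from compound 1 to compound 3 (0.44 log units; beyond the scatter), since it also swapped the fluoro-bearing ring for one carrying a larger fluorine-containing group, 3-(trifluoromethyl)phenyl in place of 2-fluorophenyl. That step was modest. The step of a 3.2-fold lower number from compound 1 to compound 2 (0.50 log units; beyond the scatter) touches a different ring and offers no direct guide. The change to compound 4 keeps the trifluoromethoxy group ortho to a large group rather than moving it, so a smaller effect than that seen for compound 3 is a fair expectation: a modest lowering of the number, or none beyond the scatter.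

Compound 4 is therefore expected to give about 22000 nM, with a plausible range from 8000 nM to 60000 nM. That estimate corresponds to an expected step of a 1.6-fold lower number from compound 1 to compound 4 (0.21 log units; within the scatter).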

Compound 4, half-maximal inhibitory concentration: > 50000 nM
Compound 4: a limit, no number; the forecaster's own chance of this, stated with the estimate: 10%; middle value at least 2.2-fold (0.35 log units) away from the limit.
By their numbers in this assay, from the lowest: compounds 2 and 3 (each within the scatter of the next); then compound 1. At a limit, above all of these: compound 4.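

In this assay compound 4 gives > 50000 nM, which is a limit of the assay and not a number. The step reads an at least 1.4-fold higher number from compound 1 to compound 4 (0.14 log units; that floor lies within the scatter), so trifluoromethoxy in place of fluoro, ortho to a large group, is the first change to compound 1 shown here that does not lower the number, whereas the other change on this ring gave a 2.7-fold lower number from compound 1 to compound 3 (0.44 log units; beyond the scatter). A fluorine-containing group with more heavy atoms on this ring therefore does not lower the number in every case, but the size of the change at this position cannot be read, since the measurement stops at a limit and its floor lies within the scatter: the limit of > 50000 nM in this assay, at which 1 of the 4 values shown sits.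

The compounds shown leave open whether the number would fall or rise with a methoxy, a chloro or an amine at this same position, ortho to a large group, in place of fluoro. They also leave open how compound 4 truly compares with compound 1, as only a value measured inside the range of the assay could settle that.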